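Cyano in place of methoxy: what compound 4 may show

A few compounds are considered here, and "the series" means these few. Any claim that something is new, unique, unknown or untested is made for them only; others in the source may bear on it.

In an ADME assay on microsomes from liver (Homo sapiens) for metabolic stability, read by LC-MS, using NADPH, with stated times of 6 min and 10 min, tested at 0.5 uM (on this read-out higher numbers stand for a more stable compound and lower numbers for a less stable compound), compound 2 (`COc1ccc(-c2cc(Cl)c3c(N)ncnn23)cc1N1CCN(C(C)=O)C(C)(C)C1=O`) reads 94% and takes the middle place among three numbers, within the scatter of both others. Compound 1 (`CC(=O)N1CCN(c2cccc(-c3cc(Cl)c4c(N)ncnn34)c2C)C(=O)C1(C)C`) stands at 84% on the same read-out, and compound 3 (`CC(=O)N1CCN(c2cc(-c3cc(Cl)c4c(N)ncnn34)ccc2S(C)(=O)=O)C(=O)C1(C)C`) stands at 100% there. Compound 4 (`CC(=O)N1CCN(c2cc(-c3cc(Cl)c4c(N)ncnn34)ccc2C#N)C(=O)C1(C)C`) is still unmeasured and departs from compound 2 by a single exchange (cyano in place of methoxy on an aromatic carbon), cyano in place of methoxy on an aromatic carbon. Going by the values given here, one measured step bears on this: methylsulfonyl in place of methoxy on an aromatic carbon gave a number 6 percentage points higher from compound 2 to compound 3 (within the scatter) and on that ground no step beyond the scatter is expected in this assay for the cyano exchange. Among the compounds with values here, the single step is thin support, and the data hold no measured compound with a cyano group. The estimated step is a number 1 percentage points higher from compound 2 to compound 4 (within the scatter) and no more than that is expected. For compound 4 the estimate is 95% with an expected range from 84% to 100% on this read-out.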

Compound 4, percent of the compound remaining: 90%
For compound 4 the middle estimate is 5 percentage points above the measured one; measured number inside the range.
By their numbers in this assay, from the lowest: compounds 1, 4, 2 and 3 (each within the scatter of the next, the first and the last beyond it).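

At this aromatic carbon, ortho to a large group and para to a large group, a cyano group now stands alongside methoxy and methylsulfonyl. In this assay, going by these compounds alone, the exchange for methoxy gives a number 4 percentage points lower from compound 2 to compound 4 (within the scatter), and the exchange for methylsulfonyl gives a number 10 percentage points lower from compound 3 to compound 4 (within the scatter), so all three groups at this place read alike within the scatter, which the single earlier step could not show for more than two groups. Nothing measured here gives a reason for these numbers.

On these data alone, it remains open whether an amine, a carboxylic acid or a longer alkoxy chain on this carbon would still read alike with these three groups. Also open, as far as these compounds go, is whether the cyano exchange would read the same with the acetyl group of the shared structure replaced by another group.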